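A few compounds are considered here, and "the series" means these few. Any claim that something is new, unique, unknown or untested is made for them only; others in the source may bear on it.

Measured compounds:

compound 1 `Cc1nnc(Sc2cc(NC(=O)c3ccc(Cl)cc3)c3ccccc3c2O)s1` — > 100000 nM
compound 2 `O=C(Nc1cc(Sc2ncn[nH]2)c(O)c2ccccc12)c1cccc(Cl)c1` — > 100000 nM

Of the compounds shown here, two have been tested in a functional assay on MDA-MB-231 cells (Homo sapiens) for antiproliferative activity, read by MTT assay, with a stated time of 48 h; a higher number here means a weaker inhibitor, a lower number a stronger inhibitor. Compound 1 gives > 100000 nM, which is a limit of the assay and not a number. Compound 2 gives > 100000 nM, again a limit rather than a number. Compound 1 therefore stands nowhere in particular on a scale of measured values: both values recorded so far sit at the limit of > 100000 nM in this assay, at which 2 of the 2 values shown sit, so neither compound shows measurable inhibition of these cells.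

Compound 3 `O=C(Nc1cc(Sc2nncs2)c(O)c2ccccc12)c1ccc(Cl)cc1` has not been tested. It differs from compound 1 by hydrogen in place of methyl on an aromatic carbon, a hydrogen in place of methyl on an aromatic carbon. Among the measured compounds shown here, no step between measured compounds is available to calibrate such a change. With compound 1 resting at the limit, the expected step that the limit leaves unreadable from compound 1 to compound 3 is none beyond the scatter, and compound 3 is expected to remain at or around the limit. Compound 3 is estimated at 150000 nM, within a range of 30000 nM to 1000000 nM.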

Compound 3, half-maximal inhibitory concentration: > 100000 nM
Compound 3: only a limit was reported; the forecaster's own chance of this, stated with the estimate: 85%; the middle value lies beyond the limit too.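

Compound 3, like compound 1, rests at a limit of the assay and not at a number, so no step can be read between them: the limit of > 100000 nM in this assay, at which 3 of the 3 values shown sit.

The compounds shown leave open how far each lies beyond that limit, and whether hydrogen in place of methyl changes activity at all.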